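This account rests on a few compounds, and the source may have more. Where it says the series, first, only, none or still open, it means among the compounds named here.

Among the compounds with values here, in a functional assay on A549 cells (Homo sapiens) for antiproliferative activity, read by MTT assay, with a stated time of 72 h (a lower number here means a stronger inhibitor, a higher number a weaker inhibitor), compound 2 `O=C1COc2ccc(-c3cccc(NS(=O)(=O)c4ccc(F)cc4)c3)cc2N1C1CCCCC1` gives 14500 nM, the lower of the two numbers known; its nearest neighbour, compound 1 `O=C1COc2ccc(-c3cccc(NS(=O)(=O)c4ccc(F)cc4)c3)cc2N1c1ccc(Cl)cc1`, gives 31600 nM. Within the data shown here, the one step available, a 2.2-fold lower number from compound 1 to compound 2 (0.34 log units; beyond the scatter), alters the group on the same amide-type nitrogen in a ring. Compound 3 `O=C1COc2ccc(-c3cccc(NS(=O)(=O)c4ccc(F)cc4)c3)cc2N1` differs from compound 2 by hydrogen in place of cyclohexyl on an amide-type nitrogen in a ring. That single modest step offers little guidance for removing the group altogether, and no direction beyond the scatter is expected. Compound 3 is therefore estimated at 22000 nM, with a range of 6000 nM to 70000 nM. The expected step is a 1.5-fold higher number from compound 2 to compound 3 (0.18 log units; within the scatter).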

Compound 3, half-maximal inhibitory concentration: 32100 nM
Beside the measured number, compound 3's estimate is 1.5-fold (0.16 log units) below it; the range from low to high includes it.
By their numbers in this assay, from the lowest: compound 2; then compounds 1 and 3 (each within the scatter of the next).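

Within this assay, the step of a 2.2-fold higher number from compound 2 to compound 3 (0.35 log units; beyond the scatter) shows that the cyclohexyl group on this amide-type nitrogen gives a lower number than hydrogen does. The step of a 1.0-fold higher number from compound 1 to compound 3 (0.01 log units; within the scatter) adds that hydrogen and 4-chlorophenyl cannot be told apart here, so among these three compounds only cyclohexyl stands apart. Nothing available explains this difference. Going by these compounds, whether cyclopentyl, a straight butyl chain or benzyl would match cyclohexyl remains open. So does the effect of an amine or a carboxylic acid carried on this nitrogen.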